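A Cyclopropyl Tail in Place of the Phenethyl Arm

The compounds below may be only part of what the source reports. "The series", "measured", "known", "first", "only" and "open" are said of these compounds alone.

Compound 1 `Cc1cc(Nc2cc(-c3ccccc3)[nH]n2)n2nc(SCCCc3ccccc3)nc2n1` stands second highest among three numbers in a functional assay on MCF7 cells (Homo sapiens) for inhibition, read by MTT assay, with a stated time of 72 h (a lower number here means a stronger inhibitor, a higher number a weaker inhibitor), where compound 1 gives 3900 nM. Its nearest neighbour is compound 2 `Cc1cc(Nc2cc(-c3ccccc3)[nH]n2)n2nc(SCc3ccc(Cl)cc3)nc2n1`, which in this assay gives 8260 nM. The furthest is compound 3 `Cc1cc(Nc2ccn(Cc3nc(C)c4ccccc4n3)n2)n2nc(SCc3ccc(Br)cc3)nc2n1`, built on a different arrangement of the shared core, which in this assay gives 1430 nM, the lowest of the three.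

The unmeasured compound 4 `Cc1cc(Nc2cc(-c3ccccc3)[nH]n2)n2nc(SCC3CC3)nc2n1` differs from compound 1 in one place only: cyclopropyl in place of phenethyl on a saturated chain carbon bound to a sulfur. The sulfur-bound chain keeps its length, but the six-membered aromatic ring at its end is exchanged for a small three-membered ring.

Among the compounds with values here, only one measured step touches the same position. Going from compound 1 to compound 2, with 4-chlorophenyl in place of phenethyl on a saturated chain carbon bound to a sulfur, the change read a 2.1-fold higher number from compound 1 to compound 2 (0.33 log units; beyond the scatter). That step kept an aromatic ring while shortening the arm; compound 4 removes the aromatic ring altogether. Within the data shown here, the single measured step leaves the direction uncertain, but a step in this assay of about the size seen for compound 2, towards higher numbers, is the natural expectation, so compound 4 is expected to show a 1.9-fold higher number from compound 1 to compound 4 (0.28 log units; within the scatter). Compound 4 is therefore estimated at 7500 nM in this assay, with a range from 3000 nM to 18000 nM.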

Compound 4, half-maximal inhibitory concentration: > 50000 nM
Compound 4: a limit, no number (the forecaster's own chance of this, stated with the estimate: 10%); middle value at least 6.6-fold (0.82 log units) from the limit.
By their numbers in this assay, from the lowest: compound 3; then compound 1; then compound 2. At a limit, above all of these: compound 4.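

The value of compound 4 in this assay is a limit of the assay and not a number: the limit of > 50000 nM in this assay, at which 1 of the 4 values shown sits. At this place, on a saturated chain carbon bound to a sulfur, the earlier compounds had shown only a modest change, a 2.1-fold higher number from compound 1 to compound 2 (0.33 log units; beyond the scatter), whereas cyclopropyl in place of phenethyl gives a large one, an at least 12-fold higher number from compound 1 to compound 4 (1.10 log units; beyond the scatter). Cyclopropyl in place of 4-chlorophenyl gives an at least 6.0-fold higher number from compound 2 to compound 4 (0.78 log units; beyond the scatter), so the two compounds that differ from compound 4 in this one place, each with a six-membered aromatic ring of carbon only in the arm, both read measured numbers, while the compound with the three-membered ring reads only a limit.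

The compounds shown do not separate the loss of the aromatic ring from the loss of the other heavy atoms of the arm, since both leave together in compound 4. Going by these compounds, how a cyclohexyl ring or a longer unbranched carbon chain on the same sulfur would read in this assay stays open, and so does the actual value of compound 4 past its limit.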